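Two Hydrazide Inhibitors at the Limit, and a Shorter Chain

The source may report more compounds than this note shows. Statements on the series, on what has been measured and on what is new or still open speak of the compounds shown alone.

compound 1, `CCCNNC(=O)c1cnc(N2CCN(Cc3c[nH]c4ccccc34)CC2)nc1`: > 20000 nM
compound 2, `CCCCCCNNC(=O)c1ccc(-c2ccc(CNC(C)=O)cc2)cc1`: > 20000 nM

Both numbers come from an assay on isolated protein for inhibition of protein deacetylase HDAC6 (Homo sapiens); a lower number here means a stronger inhibitor, a higher number a weaker inhibitor. For compound 1 the value > 20000 nM is a limit of the assay, not a measured number. For compound 2 the value > 20000 nM is likewise a limit. (the limit of > 20000 nM in this assay, at which 2 of the 2 values shown sit). Compound 2 therefore stands at the limit itself, and nothing in the numbers shown separates it from compound 1.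

Compound 3, `CCCNNC(=O)c1ccc(-c2ccc(CNC(C)=O)cc2)cc1`, differs from compound 2 in one place: hydrogen in place of propyl on a saturated chain carbon, three bonds along the chain from an amine nitrogen. For the measured compounds named here, no step between measured compounds is available to set a size for this change. Compound 2 gives only a limit, so no step in either direction can be read from it. The expected step that the limit leaves unreadable from compound 2 to compound 3 is therefore one of no change beyond the scatter. Compound 3 is expected to give 30000 nM, with a range from 8000 nM to 150000 nM.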

Compound 3, half-maximal inhibitory concentration: > 20000 nM
Compound 3: no number, only a limit; the forecaster's own chance of this, stated with the estimate: 85%; the middle value is on the limit's open side.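

In this assay compound 3 gives > 20000 nM, which is a limit of the assay. No step can be read between compound 2 and compound 3, because both stand at that limit: the limit of > 20000 nM in this assay, at which 3 of the 3 values shown sit.

The compounds shown leave open whether hydrogen in place of propyl changes anything in this assay.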